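Changing the aryl group of compound 3

This account rests on a few compounds, and the source may have more. Where it says the series, first, only, none or still open, it means among the compounds named here.

In a functional assay on KBVIN cells (Homo sapiens) for antiproliferative activity, read by sulforhodamine B assay, with a stated time of 3 days (a higher number here means that more compound is needed for the effect, a lower number that less compound is needed), compound 1 (`CCC1=C(O)c2c(oc(-c3ccc(C(C)C)cc3)cc2=O)C(CC)(CC)C1=O`) gives 1.08 uM, compound 2 (`CCC1=C(O)c2c(oc(-c3ccc(O)cc3)cc2=O)C(CC)(CC)C1=O`) gives 20.6 uM, and compound 3 (`CCC1=C(O)c2c(oc(-c3ccccc3F)cc2=O)C(CC)(CC)C1=O`) gives 3.93 uM, the middle of the three numbers. Compound 4 (`CCC1=C(O)c2c(oc(-c3ccc(C)c(Cl)c3)cc2=O)C(CC)(CC)C1=O`) has 3-chloro-4-methylphenyl in place of 2-fluorophenyl on an aromatic carbon. Changes to this same group have mattered: a 3.6-fold higher number from compound 1 to compound 3 (0.56 log units; beyond the scatter), while a 5.2-fold lower number from compound 2 to compound 3 (0.72 log units; beyond the scatter). The largest was a 19-fold higher number from compound 1 to compound 2 (1.28 log units; beyond the scatter). The entering group has no hydroxy and, like the 4-isopropylphenyl of compound 1, carries a hydrocarbon substituent, so a small move toward lower numbers is expected. For the measured compounds named here, no measured compound carries chlorine. The estimated step is a 2.0-fold lower number from compound 3 to compound 4 (0.29 log units; within the scatter). Compound 4 is expected at 2 uM, within a range of 0.7 uM to 6 uM.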

Compound 4, concentration for half-maximal effect: 2.15 uM
Estimate against measurement, compound 4: 1.1-fold (0.03 log units) below, within the range that was stated.
By their numbers in this assay, from the lowest: compounds 1, 4 and 3 (each within the scatter of the next, the first and the last beyond it); then compound 2.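

In this assay, for the compounds shown here, the 3-chloro-4-methylphenyl group of compound 4, the first group here to carry chlorine, cannot be separated from either 2-fluorophenyl (a 1.8-fold lower number from compound 3 to compound 4 (0.26 log units; within the scatter)) or 4-isopropylphenyl (a 2.0-fold higher number from compound 1 to compound 4 (0.30 log units; within the scatter)), although those two groups differ from each other beyond the scatter. Against 4-hydroxyphenyl the change is clear (a 9.6-fold lower number from compound 2 to compound 4 (0.98 log units; beyond the scatter)), so among these four compounds only compound 2 stands well apart. No measurement here explains these results. Still open, from the compounds shown here alone, is whether 3-chlorophenyl or 4-methylphenyl alone would match compound 4, and how an amine or a carboxylic acid on this aryl ring would compare with the hydroxy of compound 2.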